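Sulfonyl aryl variation in the piperazine sulfonamide series

A few compounds are considered here, and "the series" means these few. Any claim that something is new, unique, unknown or untested is made for them only; others in the source may bear on it.

Two members of the series carry numbers in a functional assay on SGC-7901 cells (Homo sapiens) for cytotoxicity, read by MTT assay, with a stated time of 48 h; on this read-out lower numbers stand for stronger inhibition and higher numbers for weaker inhibition. Compound 1 `CCN(CC)c1ccc2cc(C(=O)c3ccc(N4CCN(S(=O)(=O)c5ccc(C(F)(F)F)cc5)CC4)cc3)oc2c1`, with a 4-(trifluoromethyl)phenyl group on the sulfonyl sulfur, gives 170 nM. Compound 2 `CCN(CC)c1ccc2cc(C(=O)c3ccc(N4CCN(S(=O)(=O)c5ccc(Br)c(F)c5)CC4)cc3)oc2c1` gives only a limit of the assay, > 40000 nM, so compound 2 sits at the limit of > 40000 nM in this assay, at which 1 of the 2 values shown sits, and no number is known for it. For the measured compounds named here, the one measured step, an at least 230-fold higher number from compound 1 to compound 2 (2.37 log units; beyond the scatter), is therefore large and runs toward weaker inhibition.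

Compound 3 `CCN(CC)c1ccc2cc(C(=O)c3ccc(N4CCN(S(=O)(=O)c5ccc(C)cc5)CC4)cc3)oc2c1` differs from compound 2 by 4-methylphenyl in place of 4-bromo-3-fluorophenyl on a sulfonyl sulfur. Going by the values given here, the only step that bears on this change is the one from compound 1 to compound 2, which shows that exchanging the aryl group on the sulfonyl sulfur can move the number across the whole measured span. Since compound 2 stands at a limit, the change to compound 3 can only stay at that limit or move toward stronger inhibition; the measured step gives no hint how far. The estimate for compound 3 is 3000 nM, within 200 nM to 40000 nM, meaning an expected step of an at least 13-fold lower number from compound 2 to compound 3 (1.12 log units; beyond the scatter) toward stronger inhibition, with a real chance that compound 3 also reports only a limit.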

Compound 3, half-maximal inhibitory concentration: > 40000 nM
Compound 3: no number, only a limit; the forecaster's own chance of this, stated with the estimate: 35%; middle value at least 13-fold (1.12 log units) away from the limit.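

In this assay compound 3 reports > 40000 nM, which is a limit of the assay and not a number. Methyl in place of trifluoromethyl on an aromatic carbon, with the rest of the structure unchanged, gives an at least 230-fold higher number from compound 1 to compound 3 (2.37 log units; beyond the scatter), so this single exchange is enough to lose the readable number, and 4-(trifluoromethyl)phenyl remains the only group on the sulfonyl sulfur shown that gives one. The step between the two limit compounds cannot be read, so 4-methylphenyl and 4-bromo-3-fluorophenyl cannot be put in any order here, and the series so far divides into one readable value and a shared ceiling: the limit of > 40000 nM in this assay, at which 2 of the 3 values shown sit.

Still open, going by these compounds, is whether a nitrile or a chlorine in place of trifluoromethyl on that aromatic carbon would keep a number near that of compound 1, or whether the readable value belongs to trifluoromethyl alone. Also open, on these data alone, are how weak compound 2 and compound 3 really are, and whether a butyl chain in place of the aryl group on the sulfonyl sulfur would give a number at all.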